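The source may report more compounds than this note shows. Statements on the series, on what has been measured and on what is new or still open speak of the compounds shown alone.

Working notes on the series.

Compound 1, `Cc1ccc(CS/C(=C/c2ccccc2F)C(=O)c2ccc(Cl)cc2)cc1`, is one of two measured members of this set. In a functional assay on DU-145 cells (Homo sapiens) for inhibition, read by trypan blue exclusion, with a stated time of 96 h (on this read-out higher numbers stand for weaker inhibition of growth and lower numbers for stronger inhibition of growth), compound 1 gives 10000 nM. The second measured member, compound 2, `Cc1ccsc1/C=C(/SCc1ccc(Cl)cc1Cl)C(=O)c1ccc(Cl)cc1`, in this assay gives 10000 nM. On the digits shown, compound 1 stands level with compound 2; the two values lie within the scatter of each other, and no order between them can be read from these numbers. For the measured compounds named here, no step between measured compounds that differ in one place is available in this set, so nothing here tells how any single change on the shared core moves the read-out.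

Compound 3, `CSc1ccc(/C=C(/SCc2ccc(C)cc2)C(=O)c2ccc(Cl)cc2)cc1`, has not yet been measured. It differs from compound 1 in one place: 4-(methylsulfanyl)phenyl in place of 2-fluorophenyl on a double-bonded chain carbon bound to a double-bonded chain carbon. Nothing in the measured pair speaks to this change, so the expectation is a step of no size beyond the scatter, in neither direction, from compound 1 to compound 3 in this assay, that is no change at the digits printed from compound 1 to compound 3 (within the scatter). For compound 3 in this assay the estimate is therefore 10000 nM, with a range from 4000 nM to 25000 nM, resting on compound 1 at 10000 nM.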

Compound 3, concentration for 50% growth inhibition: 25000 nM
For compound 3 the middle estimate is 2.5-fold (0.40 log units) below the measured one; measured number inside the range.
By their numbers in this assay, from the lowest: compounds 1 and 2 (each within the scatter of the next); then compound 3.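

For the compounds shown here, this is the first step in the set that can be read at a single place: in this assay, putting 4-(methylsulfanyl)phenyl in place of 2-fluorophenyl on a double-bonded chain carbon bound to a double-bonded chain carbon gives a 2.5-fold higher number from compound 1 to compound 3 (0.40 log units; beyond the scatter). The position is thus not silent on this read-out, and this change moves the number modestly towards weaker inhibition of growth, beyond the scatter. Nothing at hand ties the step to any feature of either group, whether the 2-fluorophenyl that leaves or the 4-(methylsulfanyl)phenyl that enters.

On these data alone, it remains open whether the step reflects the loss of 2-fluorophenyl or the arrival of 4-(methylsulfanyl)phenyl, and a single step gives no trend at this place. A plain phenyl, or a phenyl carrying an amine or a carboxylic acid, at this place would help separate the two, and the compounds shown do not say whether any group there would give a lower number than compound 1 does.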